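From methyl to dichloromethyl on an aromatic carbon

The compounds below may be only part of what the source reports. "The series", "measured", "known", "first", "only" and "open" are said of these compounds alone.

In a functional assay (Homo sapiens) (a higher number here means a weaker inhibitor, a lower number a stronger inhibitor), compound 3 `Cc1cccc(-c2nccc3nc(N)nn23)c1` gives 5500 nM, which lies between compound 1 `Nc1nc2ccnc(-c3cccc(C(F)(F)F)c3)n2n1` at 2200 nM; 2200 nM (2 entries) and compound 2 `C#Cc1cccc(-c2nccc3nc(N)nn23)c1` at 12600 nM; 12600 nM (2 entries). Compound 4 `Nc1nc2ccnc(-c3cccc(C(Cl)Cl)c3)n2n1` keeps the shared core but carries dichloromethyl in place of methyl on an aromatic carbon. Among the compounds with values here, no measured pair isolates this change, so the only guide is compound 1, which has trifluoromethyl in that place and gives 2200 nM; 2200 nM (2 entries). In this assay, a modest strengthening is therefore expected, an estimated step of a 1.8-fold lower number from compound 3 to compound 4 (0.26 log units; within the scatter) that may barely clear the usual scatter. For compound 4, the estimated value is 3000 nM, with an expected range from 1000 nM to 9000 nM.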

Compound 4, half-maximal inhibitory concentration: 1000 nM
Compound 4: middle estimate off by 3.0-fold (0.48 log units), on the high side; measured number inside the range.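

In this assay, within the data shown here, putting dichloromethyl in place of methyl on this aromatic carbon gives a 5.5-fold lower number from compound 3 to compound 4 (0.74 log units; beyond the scatter), the first step here between compounds that differ in one place. It shows that the number in this assay responds to the group at this position, and that a group with chlorine can give a stronger inhibitor than methyl. Nothing here explains the change.

From the compounds shown here alone, whether one chlorine, as in chloromethyl, would give a similar step remains open. So does the effect of an amine or a carboxylic acid at this position.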